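Changing the triazole substituent in a diaryl urea series

The compounds below may be only part of what the source reports. "The series", "measured", "known", "first", "only" and "open" are said of these compounds alone.

Measured compounds:
compound 1 `Cn1ncnc1-c1cc(Oc2ccc(NC(=O)Nc3cccc(C(F)(F)F)c3)cc2F)ccn1` gives 22400 nM
compound 2 `CCN(CC)CCn1cnnc1-c1cc(Oc2ccc(NC(=O)Nc3ccccc3C(F)(F)F)cc2F)ccn1` gives 23500 nM
compound 3 `CCN(CC)CCn1cnnc1-c1cc(Oc2ccc(NC(=O)Nc3ccc(Cl)cc3Cl)cc2F)ccn1` gives 4280 nM

All three compounds were tested in an ADME assay on WI-38 cells (Homo sapiens) for cytotoxicity, read by MTT assay, with a stated time of 72 h; a lower number here means a stronger inhibitor, a higher number a weaker inhibitor. Compound 1 stands second highest of the three numbers: compound 2 lies within the scatter of it, while compound 3 shows a lower number, beyond the scatter. Going by the values given here, the only step between compounds that differ in one place is a 5.5-fold lower number from compound 2 to compound 3 (0.74 log units; beyond the scatter), and that step concerns the aryl group on the urea nitrogen, not the triazole.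

Compound 4 `CN(C)CCCn1cnnc1-c1cc(Oc2ccc(NC(=O)Nc3cccc(C(F)(F)F)c3)cc2F)ccn1` differs from compound 1 by 4-(3-(dimethylamino)propyl)-4H-1,2,4-triazol-3-yl in place of 1-methyl-1H-1,2,4-triazol-5-yl on an aromatic carbon. Among the compounds with values here, no measured pair differs only at this position, so the one measured step does not bear directly on it. Compounds 1 and 2, which differ at the triazole substituent and also in where the trifluoromethyl sits, give numbers within the scatter of each other. On that basis the expected step is a 1.0-fold lower number from compound 1 to compound 4 (0.01 log units; within the scatter), none beyond the scatter. Compound 4 is therefore estimated at 22000 nM, with a range from 9000 nM to 55000 nM.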

Compound 4, half-maximal inhibitory concentration: 11600 nM
Beside the measured number, compound 4's estimate is 1.9-fold (0.28 log units) above it, within the range that was stated.
By their numbers in this assay, from the lowest: compound 3; then compounds 4, 1 and 2 (each within the scatter of the next, the first and the last beyond it).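

In this assay, going by these compounds alone, this is the first pair that differs only in the triazole substituent, unlike compounds 1 and 2, which also differ in where the trifluoromethyl sits. Replacing 1-methyl-1H-1,2,4-triazol-5-yl with 4-(3-(dimethylamino)propyl)-4H-1,2,4-triazol-3-yl gives a 1.9-fold lower number from compound 1 to compound 4 (0.29 log units; within the scatter), so at this position, on an aromatic carbon next to the ring nitrogen, going from 6 to 11 heavy atoms leaves the number within the usual scatter. No supporting measurement is available to explain this result.

The compounds shown leave open whether a longer chain, or a morpholine or carboxylic acid at the chain end, would move the number beyond the scatter. They also leave open whether the step seen with 2,4-dichlorophenyl on the urea would hold alongside the chain in compound 4.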